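The compounds below may be only part of what the source reports. "The series", "measured", "known", "first", "only" and "open" are said of these compounds alone.

Compound 1 `O=C(O)CCc1ccc(-c2ccc3cnn(-c4ccccn4)c3c2)cc1` gives 4500 nM in a functional assay on cells for agonist activity at Free fatty acid receptor 1 (Mus musculus), read by FLIPR and calcium flux, with a stated time of 5 min; a lower number here means that less compound is needed, a higher number that more compound is needed for the effect.
Compound 2 `O=C(O)CCc1ccc(-c2cc(F)c3cnn(-c4ccccn4)c3c2)cc1` gives 2600 nM in this assay.
Compound 3 `COc1nn(-c2ccccn2)c2cc(-c3ccc([C@H]4C[C@@H]4C(=O)O)cc3)cc(F)c12` gives only a limit of the assay in this assay, > 100000 nM.

Compounds 1 and 2 share a core and differ in one place: hydrogen in place of fluoro on an aromatic carbon. The measured step for that change is a 1.7-fold higher number from compound 2 to compound 1 (0.24 log units; within the scatter), so the two compounds cannot be told apart by this measurement.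

Compound 3 is built on a different core, and the difference between the two cores is not broken down here. What is known of compound 3 is the limit of > 100000 nM in this assay, at which 1 of the 3 values shown sits, so no number for it exists, only the limit.

Compound 4 `COc1nn(-c2ccccn2)c2cc(-c3ccc([C@H]4C[C@@H]4C(=O)O)cc3)ccc12` has not yet been measured in this assay. It is related to compound 3 by the same change that relates compound 2 to compound 1: hydrogen in place of fluoro on an aromatic carbon. The surroundings of the place are described in the same words for both pairs, so the change is the same change.

Since the measured step for this change is within the scatter, the expected step from compound 3 to compound 4 is likewise small, a step that the limit leaves unreadable from compound 3 to compound 4. Because compound 3 itself stands at the limit of > 100000 nM in this assay, at which 1 of the 3 values shown sits, compound 4 is expected to stay in the same region, most probably again at or beyond the limit. The estimate for compound 4 is 150000 nM, within a range of 40000 nM to 600000 nM.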

Compound 4, half-maximal effective concentration: > 100000 nM
Compound 4: a limit, no number (the forecaster's own chance of this, stated with the estimate: 75%); the middle value does not contradict the limit.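

Compound 3 and compound 4 both end at a limit of the assay rather than at a number, so the step between them cannot be read: the limit of > 100000 nM in this assay, at which 2 of the 4 values shown sit. The compounds shown leave open how much of compound 3 or compound 4 would be needed for the effect in this assay, and whether hydrogen in place of fluoro changes anything on their shared core.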